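The source may report more compounds than this note shows. Statements on the series, on what has been measured and on what is new or still open speak of the compounds shown alone.

Measured compounds: compound 1 `CC(C)(C)OC(=O)NCCCCNC(=O)CN1CN(c2ccccc2)C2(CCN(C(=O)c3ccc(C(C)(C)C)cc3)CC2)C1=O`, compound 2 `CC(C)(C)OC(=O)NC1CCN(C(=O)CN2CN(c3ccccc3)C3(CCN(C(=O)c4ccc(C(C)(C)C)cc4)CC3)C2=O)CC1`, compound 3 `CCc1nn(CC)c(C2CCN(C(=O)CN3CN(c4ccccc4)C4(CCN(C(=O)c5ccc(C6CCCCC6)cc5)CC4)C3=O)CC2)c1C`.

The three share one core, a spiro amide carrying a tert-butylbenzoyl or a cyclohexylbenzoyl group and an acetamide side chain. In an assay on HEK293 cells for displacement of a labelled ligand from NPC1-like intracellular cholesterol transporter 1 (Homo sapiens) (on this read-out lower numbers stand for stronger inhibition and higher numbers for weaker inhibition), compound 1 gives "not determined" (no result reported), and compound 3 likewise gives "not determined" (no result reported). Only compound 2, with its tert-butoxycarbonylamino-piperidine amide, has a number: in this assay compound 2 gives 8300 nM, a weak value. So compound 1 stands without a number of its own, and only compound 2 marks the range in which this series has been seen.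

Compound 4 `CC(C)(C)c1ccc(C(=O)N2CCC3(CC2)C(=O)N(CC(=O)NCCO)CN3c2ccccc2)cc1` is reached from compound 1 by the change (hydroxy in place of 2-((tert-butoxycarbonyl)amino)ethyl on a saturated chain carbon, two bonds along the chain from an amide-type nitrogen). The side chain shrinks to a hydroxyethyl amide. For the measured compounds named here, no measured step shows what such a shortening does here, so no direction can be given beyond saying the new amide is expected to remain in the weak region that compound 2 occupies. For compound 4 the estimated value in this assay is 12000 nM, within 2500 nM to 60000 nM.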

Compound 4, half-maximal inhibitory concentration: 1000 nM
Estimate against measurement, compound 4: 12-fold (1.08 log units) above; the whole stated range lies above it.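

In this assay, for the compounds shown here, compound 1 gives "not determined" (no result reported) while compound 4 gives 1000 nM so no step between compound 1 and compound 4 can be read. No evidence bears on this result. The compounds shown leave open how changes in the side chain on the shared core move this value.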